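This account rests on a few compounds, and the source may have more. Where it says the series, first, only, none or still open, it means among the compounds named here.

Compound 1 `CCCC(Oc1ccc(-n2cc(OC)cn2)cc1)c1ccc(C(=O)NCCC(=O)O)cc1`: > 23000 nM. Compound 2 `CC(C)CC(Oc1ccc(-n2cc(C(F)(F)F)cn2)cc1)c1ccc(C(=O)NCCC(=O)O)cc1`: 3400 nM.

In a functional assay on cells for antagonist activity at Glucagon receptor (Homo sapiens), read by cAMP accumulation, in the presence of a further agent that is not named here (a lower number here means a stronger inhibitor, a higher number a weaker inhibitor), compound 1 gives only a limit, > 23000 nM, so its position rests on the limit of > 23000 nM in this assay, at which 1 of the 2 values shown sits, and no number is fixed for it. Compound 2 gives 3400 nM in this assay. Compound 3 `CCCC(Oc1ccc(-n2cc(Cl)cn2)cc1)c1ccc(C(=O)NCCC(=O)O)cc1` differs from compound 1 by chloro in place of methoxy on an aromatic carbon. Among the compounds with values here, no measured pair here shows how such a change moves this assay, so only a modest step toward stronger inhibition is expected. Compound 3 is expected to give 8000 nM, between 2500 nM and 25000 nM. For compound 3 this means an expected step of an at least 2.8-fold lower number from compound 1 to compound 3 (0.45 log units; beyond the scatter).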

Compound 3, antagonist equilibrium constant: 6500 nM
Estimate against measurement, compound 3: 1.2-fold (0.09 log units) above, within the range that was stated.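

Within the data shown here, replacing 4-methoxy-1H-pyrazol-1-yl with 4-chloro-1H-pyrazol-1-yl gives the only direct reading of this position in this assay, with an at least 3.5-fold lower number from compound 1 to compound 3 (0.54 log units; beyond the scatter). The substituent on this aromatic carbon therefore moves the result by more than the usual scatter on the shared core. The size of the step remains a floor, as its starting point is a limit: the limit of > 23000 nM in this assay, at which 1 of the 3 values shown sits.

Compound 2 differs from compound 3 in more than one place, so the effect of trifluoromethyl at this position is not separated from that of the chain. Going by these compounds, how a nitrile, a methyl or a bromo group at this carbon would read on the core of compound 3 remains open.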